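From fluoro to nitro on a shared core

The source may hold more compounds than are shown below. What is called first, only, known or untested is meant among the compounds shown, and "the series" means these compounds.

Compound 1 `COc1cc(OC)c(C(=O)/C=C/c2ccc(Cl)cc2)c(OC)c1` with 7500 nM measured
Compound 2 `COc1cc(OC)c(C(=O)/C=C/c2ccc(F)cc2)c(OC)c1` with 7700 nM measured

Both values come from a functional assay on MCF7 cells (Homo sapiens) for cytotoxicity, with a stated time of 48 h (a higher number here means a weaker inhibitor, a lower number a stronger inhibitor), and they cannot be told apart. Within the data shown here, the single measured step is a 1.0-fold higher number from compound 1 to compound 2 (0.01 log units; within the scatter) and it leaves compound 2 level with compound 1 on the numbers so far.

Compound 3 `COc1cc(OC)c(C(=O)/C=C/c2ccc([N+](=O)[O-])cc2)c(OC)c1` has not been measured yet. It differs from compound 2 by one change on the shared core, nitro in place of fluoro on an aromatic carbon in full, which is nitro in place of fluoro on an aromatic carbon.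

Only the fluoro in place of chloro swap bears on this, and that step a 1.0-fold higher number from compound 1 to compound 2 (0.01 log units; within the scatter) made no visible difference. Among the measured compounds shown here, no nitro compound has been measured, so this is a weak guide and the range stays wide. The expected step is a 1.2-fold lower number from compound 2 to compound 3 (0.07 log units; within the scatter) with nothing beyond the scatter expected in this assay for now. For compound 3 the estimate is 6500 nM with an expected range from 2500 nM to 17000 nM in this test.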

Compound 3, half-maximal inhibitory concentration: 5000 nM
Estimate against measurement, compound 3: 1.3-fold (0.11 log units) above; the range from low to high includes it.
By their numbers in this assay, from the lowest: compounds 3, 1 and 2 (each within the scatter of the next).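

Swapping a single fluoro atom for the larger nitro group, with 3 heavy atoms and 2 hydrogen-bond acceptors, gives no step beyond the scatter in this assay (a 1.5-fold lower number from compound 2 to compound 3 (0.19 log units; within the scatter)). The comparison with the chloro compound reads the same way (a 1.5-fold lower number from compound 1 to compound 3 (0.18 log units; within the scatter)), so this position on the six-membered aromatic ring, para to a large group, now accepts three different groups with no clear separation in the numbers, which the fluoro and chloro pair alone could not show for a group of this size. The data offer no measured property of these groups that could explain this result.

Still open, as far as these compounds go, is whether any group at this position can move the number beyond the scatter. Among these compounds, an amine, a carboxylic acid or a longer chain such as butyl would test that, since all three compounds so far sit close together.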